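The source may report more compounds than this note shows. Statements on the series, on what has been measured and on what is new or still open speak of the compounds shown alone.

Compound 1 has the structure `Clc1ccc(Cn2cncc2CNc2cccc(-c3ccccc3)c2)cc1` and in a toxicity assay on NIH3T3 cells (Mus musculus) for cytotoxicity, read by resazurin assay (a lower number here means that less compound is needed, a higher number that more compound is needed for the effect), compound 1 gives 10000 nM. Compound 2 has the structure `c1ccc(-c2ccc(Cn3cncc3CNc3ccccc3-c3ccccc3)cc2)cc1` and in this assay compound 2 reaches only a limit, > 10000 nM. Compound 3 has the structure `COC(=O)c1ccc(NCc2cncn2Cc2ccc(Cl)cc2)cc1-c1ccccc1` and in this assay compound 3 gives 25000 nM.

Among the two numbers shown, compound 3 holds the highest; its nearest neighbour is compound 1, reached by the only measured step, a 2.5-fold higher number from compound 1 to compound 3 (0.40 log units; beyond the scatter), and the third value is the limit of > 10000 nM in this assay, at which 1 of the 3 values shown sits. Compound 4, with the structure `COC(=O)c1ccc(NCc2cncn2Cc2ccccc2[N+](=O)[O-])cc1-c1ccccc1`, differs from compound 3 in one place: 2-nitrophenyl in place of 4-chlorophenyl on a saturated chain carbon bound to an aromatic nitrogen. Among the measured compounds shown here, no measured step touches this position, since the single step seen concerns methoxycarbonyl in place of hydrogen on an aromatic carbon elsewhere in the shared core. There is therefore no basis for expecting a step beyond the scatter in this assay in either direction. Compound 4 is accordingly estimated at 25000 nM, with a range from 10000 nM to 60000 nM, which means an expected step of no change at the digits printed from compound 3 to compound 4 (within the scatter).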

Compound 4, half-maximal effective concentration: 10000 nM
Beside the measured number, compound 4's estimate is 2.5-fold (0.40 log units) above it; measured number inside the range.
By their numbers in this assay, from the lowest: compounds 1 and 4 (each within the scatter of the next); then compound 3.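

The earlier compounds shown here said nothing about this position, and in this assay it proves able to move the number: 2-nitrophenyl in place of 4-chlorophenyl gives a 2.5-fold lower number from compound 3 to compound 4 (0.40 log units; beyond the scatter). This step runs in the opposite direction to the methoxycarbonyl change on the aromatic carbon, so each of the two positions tested shifts the number beyond the scatter. Nothing in the data shown accounts for this step.

As far as these compounds go, the change swaps both the substituent and its place on the phenyl ring, so it remains open which of the two carries the step, a question that 4-nitrophenyl or 2-chlorophenyl at this position would help to settle. Also open, from the compounds shown here alone, is how this assay would read with a 2-aminophenyl group here.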